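Weak Inhibitors Sharing One Core, Varied at a Sulfur

The source may hold more compounds than are shown below. What is called first, only, known or untested is meant among the compounds shown, and "the series" means these compounds.

Compound 1, `CC(C)c1cc(OCC(=O)[C@H](CC(=O)O)NC(=O)[C@@H](NC(=O)COc2cccc3ccccc23)C(C)C)no1`, in a functional assay on Jurkat cells (Homo sapiens) for inhibition (on this read-out higher numbers stand for weaker inhibition and lower numbers for stronger inhibition), reaches only the limit > 200000 nM.
Compound 2, `CC(C)[C@H](NC(=O)COc1cccc2ccccc12)C(=O)N[C@@H](CC(=O)O)C(=O)CSc1nnc(-c2ccccc2)o1`, gives in this assay a value of 150000 nM.
Compound 3, `CC(C)[C@H](NC(=O)COc1cccc2ccccc12)C(=O)N[C@@H](CC(=O)O)C(=O)CSc1nc2ccccc2[nH]1`, in this assay again reaches only the limit > 200000 nM.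

Compound 3 therefore stands at the top of what this assay can report; its value is a limit, not a number, and the limit of > 200000 nM in this assay, at which 2 of the 3 values shown sit, shows that compound 1 shares that limit. The step of an at least 1.3-fold higher number from compound 2 to compound 3 (0.12 log units; that floor lies within the scatter) is readable only as a floor, and a step that the two limits leave unreadable from compound 1 to compound 3 cannot be read at all, since both ends are limits. The step of an at least 1.3-fold lower number from compound 1 to compound 2 (0.12 log units; that floor lies within the scatter) is likewise only a floor, and it lies within the scatter.

Compound 4, `Cc1cc(C)nc(SCC(=O)[C@H](CC(=O)O)NC(=O)[C@@H](NC(=O)COc2cccc3ccccc23)C(C)C)n1`, differs from compound 3 by 4,6-dimethylpyrimidin-2-yl in place of 1H-benzimidazol-2-yl on a sulfur. Every measured change at this end of the molecule has left the inhibition weak or unreadable, so no step beyond the scatter is expected in this assay. For compound 4 the estimate is 200000 nM, between 80000 nM and 500000 nM, which means an expected step of a number no higher from compound 3 to compound 4 (the limit leaves the size open).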

Compound 4, half-maximal inhibitory concentration: > 200000 nM
Compound 4 was reported as a limit; the forecaster's own chance of this, stated with the estimate: 60%; the middle value lies on the limit itself.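

In this assay compound 4 reaches only a limit, > 200000 nM, not a number. Among the compounds shown here, a further group on the sulfur, 4,6-dimethylpyrimidin-2-yl, with one ring and no hydrogen-bond donor in place of the two rings and one donor of 1H-benzimidazol-2-yl, thus joins the compounds that this assay cannot tell apart: the limit of > 200000 nM in this assay, at which 3 of the 4 values shown sit. The one readable step is an at least 1.3-fold higher number from compound 2 to compound 4 (0.12 log units; that floor lies within the scatter), and the others, with limits at both ends, cannot be read.

As far as these compounds go, whether any group on this sulfur can give a number well clear of the limit stays open, and so far only compound 2 gives a number at all. A pyrimidine ring carrying an amine, or a plain longer carbon chain on the sulfur, would be further groups to try at this place.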